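Shortening the acid chain to a hydroxymethyl group

The compounds below may be only part of what the source reports. "The series", "measured", "known", "first", "only" and "open" are said of these compounds alone.

Of the compounds shown here, two share a core and have been measured in an assay on A10 cells for binding affinity to Endothelin-1 receptor (Rattus norvegicus); on this read-out higher numbers stand for weaker inhibition and lower numbers for stronger inhibition. Compound 1, `N#Cc1ccc(OCc2ccsc2)cc1/C=C(/CCC(=O)O)c1ccccc1`, gives 700 nM in this assay. Compound 2, `Cc1ccccc1/C(=C\c1cc(OCc2ccsc2)ccc1Br)C(=O)O`, gives 3000 nM in this assay. Compound 1 thus stands at the lower of the two numbers, and the gap between the values of compound 1 and compound 2 lies beyond the scatter of repeated measurements.

Compound 3, `N#Cc1ccc(OCc2ccsc2)cc1/C=C(/CO)c1ccccc1`, has not yet been measured. It differs from compound 1 in one place: hydroxy in place of carboxymethyl on a saturated chain carbon bound to a double-bonded chain carbon. Among the compounds with values here, no pair among the measured compounds shows this change, so there is no measured step to lean on.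

The account expects compound 3 to give a higher number than compound 1 in this assay, by a step larger than the scatter, estimated as a 7.1-fold higher number from compound 1 to compound 3 (0.85 log units; beyond the scatter). The estimated value for compound 3 in this assay is 5000 nM, with an expected range from 1000 nM to 30000 nM.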

Compound 3, half-maximal inhibitory concentration: 800 nM
Estimate against measurement, compound 3: 6.3-fold (0.80 log units) above; the measured number lies below the stated range.
By their numbers in this assay, from the lowest: compounds 1 and 3 (each within the scatter of the next); then compound 2.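

Replacing carboxymethyl with hydroxy on a saturated chain carbon bound to a double-bonded chain carbon, which cut one bond further out reads as 2-carboxyethyl to hydroxymethyl, gives a 1.1-fold higher number from compound 1 to compound 3 (0.06 log units; within the scatter) in this assay. On the core of compound 1, then, this place accepts the shorter hydroxymethyl chain without a change beyond the scatter, and the carboxylic acid of the 2-carboxyethyl chain is not required to keep the number at this level; compounds 1 and 2 differ in more than one place, so they could not show this. No measurement shown here bears on why the two chains read alike.

On these data alone, it remains open whether an aminomethyl group, a methoxymethyl group or a longer chain ending in hydroxy would also hold the number at this place on the shared core. Within the data shown here, it is equally open whether the same exchange would leave the number unchanged on other cores, since the single step from compound 1 to compound 3 is the only measured example of this change.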